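The source may hold more compounds than are shown below. What is called first, only, known or untested is meant among the compounds shown, and "the series" means these compounds.

Measured so far in a physicochemical assay, read by spectrophotometry, with a stated time of 15 min; a higher number here means a weaker inhibitor, a lower number a stronger inhibitor:
compound 1 `O=C(CCc1nc2ccccc2c(=O)[nH]1)N/N=C/c1ccc(O)cc1`: 300000000 nM
compound 2 `COc1cc(/C=N/NC(=O)CCc2nc3ccccc3c(=O)[nH]2)cc(OC)c1OC`: 80000000 nM
compound 3 `COc1cc(/C=N/NC(=O)CCc2nc3ccccc3c(=O)[nH]2)cc(OC)c1O`: 275000000 nM

Compound 1 sits at the upper end of this short series. Its number lies within the scatter of compound 3, while compound 2 has a number lower than both, beyond the scatter.

The next compound is compound 4 `O=C(CCc1nc2ccccc2c(=O)[nH]1)N/N=C/c1cc(O)c(O)c(O)c1`, which keeps the core of compound 1. The change is 3,4,5-trihydroxyphenyl in place of 4-hydroxyphenyl on a carbon with a double bond to nitrogen.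

Going by the values given here, only one measured step bears on this: a 3.4-fold higher number from compound 2 to compound 3 (0.54 log units; beyond the scatter), with hydrogen in place of methyl on an oxygen on an aromatic ring. It is modest, and it points to a higher number when a methyl is lost from such an oxygen. Compound 3 at 275000000 nM and compound 1 at 300000000 nM nevertheless stay within the scatter of each other despite their different rings. Among the compounds with values here, no measured compound carries the new ring itself, so the basis is thin.

In this assay no step beyond the scatter is therefore expected, and the estimated step is a 1.5-fold lower number from compound 1 to compound 4 (0.18 log units; within the scatter). For compound 4 the estimate is 200000000 nM, with an expected range from 50000000 nM to 450000000 nM.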

Compound 4, half-maximal inhibitory concentration: 45000000 nM
Estimate against measurement, compound 4: 4.4-fold (0.65 log units) above; measured number below the stated range.
By their numbers in this assay, from the lowest: compounds 4 and 2 (each within the scatter of the next); then compounds 3 and 1 (each within the scatter of the next).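

At the carbon with a double bond to nitrogen, in this assay, 3,4,5-trihydroxyphenyl in place of 4-hydroxyphenyl gives a stronger inhibitor, with a 6.7-fold lower number from compound 1 to compound 4 (0.82 log units; beyond the scatter). This is the first change at this position shown to lower the number through the ring substituents alone while the shared core stays fixed, and it shows that the position responds to what the ring carries. The earlier step, a 3.4-fold higher number from compound 2 to compound 3 (0.54 log units; beyond the scatter), showed only a rise on losing a methyl from an oxygen on an aromatic ring, so a free hydroxyl does not go with a higher number across the series, and compound 4 goes against that reading, while no measured result available here accounts for the drop.

Still open, going by these compounds, is whether the lower number of compound 4 needs the full set of hydroxyl groups on the ring or only some of them, since this single pair cannot separate their contributions. Also open, on these data alone, is whether a ring carrying an amine or a carboxylic acid in place of those hydroxyl groups would hold the number of compound 4 at this position, or whether a longer chain between the shared core and the ring would do so.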